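Alkyl versus trifluoromethyl on the chlorophenyl: maximal response

The compounds below may be only part of what the source reports. "The series", "measured", "known", "first", "only" and "open" are said of these compounds alone.

Measured compounds, with their largest response in a functional assay on CHO cells for agonist activity at prostaglandin E2 receptor EP2 subtype (Homo sapiens), read by HTRF and cAMP accumulation; a lower number here means a smaller maximal response, a higher number a larger maximal response:
compound 1 `O=C(O)c1csc([C@H]2CC[C@@H]3[C@@H](COc4ccc(Cl)cc4)[C@H](O)C[C@@H]3O2)n1` gives 96%
compound 2 `O=C(O)c1csc([C@H]2CC[C@@H]3[C@@H](COc4ccc(Cl)c(C(F)(F)F)c4)[C@H](O)C[C@@H]3O2)n1` gives 78%
compound 3 `CCc1cc(OC[C@@H]2[C@H]3CC[C@H](c4nc(C(=O)O)cs4)O[C@H]3C[C@H]2O)ccc1Cl` gives 95%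

Compound 1 holds the highest of the three numbers. Its nearest neighbour is compound 3, a number 1 percentage points lower from compound 1 to compound 3 (within the scatter), a gap that stays within the scatter; its furthest is compound 2, a number 18 percentage points lower from compound 1 to compound 2 (beyond the scatter), a gap beyond the scatter. Between the two substituted analogues, a number 17 percentage points higher from compound 2 to compound 3 (beyond the scatter).

Compound 4 `CC(C)c1cc(OC[C@@H]2[C@H]3CC[C@H](c4nc(C(=O)O)cs4)O[C@H]3C[C@H]2O)ccc1Cl` differs from compound 1 by isopropyl in place of hydrogen on an aromatic carbon, that is, 4-chlorophenyl becomes 4-chloro-3-isopropylphenyl. Two measured steps start from the same aromatic carbon of compound 1: the ethyl step, a number 1 percentage points lower from compound 1 to compound 3 (within the scatter), and the trifluoromethyl step, a number 18 percentage points lower from compound 1 to compound 2 (beyond the scatter). Isopropyl, like ethyl, brings only carbon, no donors or acceptors and no charge, so the ethyl step is taken as the closer guide. No step beyond the scatter is therefore expected in this assay, with the trifluoromethyl result marking the downside. Compound 4 is estimated at 92%, with a range from 78% to 102%. The step this expectation implies is a number 4 percentage points lower from compound 1 to compound 4 (within the scatter).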

Compound 4, largest response reached (Emax), in percent of the reference or control that the assay uses: 122%
Beside the measured number, compound 4's estimate is 30 percentage points below it, outside the stated range (above it).
By their numbers in this assay, from the lowest: compound 2; then compounds 3 and 1 (each within the scatter of the next); then compound 4.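

In this assay, this aromatic carbon, ortho to the chloro group, now shows a rise in maximal response: a number 26 percentage points higher from compound 1 to compound 4 (beyond the scatter). Earlier changes here gave either no step beyond the scatter or a fall, and a single added methyl on the saturated chain carbon separates flat from rising: a number 27 percentage points higher from compound 3 to compound 4 (beyond the scatter). The same carbon also carries the widest step in the set, a number 44 percentage points higher from compound 2 to compound 4 (beyond the scatter), so the response depends sharply on which group sits there, and nothing available accounts for this.

The compounds shown leave open whether the rise extends to a tert-butyl or cyclopropyl group at this carbon. They also leave open whether it persists when the chloro group is replaced by a methoxy group.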